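Side-chain swap at the cytotoxicity limit

The source may report more compounds than this note shows. Statements on the series, on what has been measured and on what is new or still open speak of the compounds shown alone.

Measured in a functional assay on HepG2 cells (Homo sapiens) for cytotoxicity, read by MTT assay, with a stated time of 72 h (a higher number here means a weaker inhibitor, a lower number a stronger inhibitor), all values being limits:
Compound 1 `CCN1CCN(CC(=O)Nc2ccc3[nH]c(-c4cccn4C)nc3c2)CC1`: > 50000 nM
Compound 2 `Cc1ccc(-c2nc3cc(NC(=O)CCN4CCN(C)CC4)ccc3[nH]2)cc1`: > 50000 nM
Compound 3 `Cc1ccc(-c2nc3cc(NC(=O)CN4CCCC4)ccc3[nH]2)cc1`: > 50000 nM

Compound 2 stands at a limit, > 50000 nM, and offers no number to step from. Compound 4 `Cc1ccc(-c2nc3cc(NC(=O)CCCl)ccc3[nH]2)cc1` carries chloro in place of 4-methylpiperazin-1-yl on a saturated chain carbon, two bonds along the chain from a carbonyl carbon. The nearest measured change is a step that the two limits leave unreadable from compound 2 to compound 3, which gives no size. No step beyond the scatter is expected in this assay, and no direction can be assigned, because the limit of > 50000 nM in this assay, at which 3 of the 3 values shown sit, covers every measured compound. The estimated change is a number no higher from compound 2 to compound 4 (the limit leaves the size open). Compound 4 is expected at 50000 nM, within an estimated range of 15000 nM to 100000 nM.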

Compound 4, half-maximal inhibitory concentration: > 50000 nM
Compound 4: no number, only a limit (the forecaster's own chance of this, stated with the estimate: 60%); the middle value lies on the limit itself.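

Among the compounds shown here, compound 4 gives the limit > 50000 nM and no step from compound 2 or compound 3 to compound 4 can be read: the limit of > 50000 nM in this assay, at which 4 of the 4 values shown sit. The compounds shown leave open whether any of these side chains differs from another in potency.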